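Methyl position on the ring-nitrogen aryl group

A few compounds are considered here, and "the series" means these few. Any claim that something is new, unique, unknown or untested is made for them only; others in the source may bear on it.

Measured compounds in a functional assay on the whole organism (strain Swiss albino) for inhibition, with Mus musculus as the target, in the maximal electroshock model, with a stated time of 2 h, at a dose of 25 mg/kg by the intraperitoneal route; on this read-out lower numbers stand for less inhibition and higher numbers for more inhibition at the one dose given (going by the name of the read-out):
Compound 1, `Cc1ccccc1N1C(=O)C(c2ccccc2)CC(c2ccccc2)C1=O`, gives 66.1%.
Compound 2, `Cc1ccc(N2C(=O)C(c3ccccc3)CC(c3ccccc3)C2=O)cc1`, gives 43.3%.
Compound 3, `Cc1ccccc1N1C(=O)C(c2ccccc2Cl)CC(c2ccccc2Cl)C1=O`, gives 60.6%.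

The change from compound 1 to compound 2 is 4-methylphenyl in place of 2-methylphenyl on an amide-type nitrogen in a ring, and its step is a number 22.8 percentage points lower from compound 1 to compound 2 (beyond the scatter). Compound 4, `Cc1ccc(N2C(=O)C(c3ccccc3Cl)CC(c3ccccc3Cl)C2=O)cc1`, is not yet measured; it differs from compound 3 by 4-methylphenyl in place of 2-methylphenyl on an amide-type nitrogen in a ring. This is the same kind of change, though around the place the two ring atoms each bear a 2-chlorophenyl group instead of a phenyl group. The difference between the cores of compound 1 and compound 3 is not broken down here; their values lie within the scatter of each other, while the value of compound 2 sits lower than that of compound 3 by more than the scatter. For compound 4 a step of about the earlier size is expected, a number 20.6 percentage points lower from compound 3 to compound 4 (beyond the scatter), resting on the step of a number 22.8 percentage points lower from compound 1 to compound 2 (beyond the scatter). Compound 4 is estimated at 40%, between 25% and 55%.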

Compound 4, a percentage reported as inhibition, in the whole organism at one dose (the size of the read-out at that dose, not a potency): 58.2%
Compound 4: middle estimate off by 18.2 percentage points, on the low side; the measured number lies above the stated range.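

In this assay the new step is a number 2.4 percentage points lower from compound 3 to compound 4 (within the scatter), so on the core bearing two 2-chlorophenyl groups, 4-methylphenyl in place of 2-methylphenyl gives no change that can be told from scatter. For the compounds shown here, the same change therefore does not carry over at a fixed size between these two cores: the same change on two cores in this assay, a number 22.8 percentage points lower (beyond the scatter) from compound 1 to compound 2 and a number 2.4 percentage points lower (within the scatter) from compound 3 to compound 4, 20.4 percentage points apart, beyond the scatter of two such steps This shows that the size of the step depends on the core, but it does not show what about the core sets that size, and each core supplies only a single pair.

As far as these compounds go, it remains open how the step would behave with a methoxy group or a longer chain in place of the methyl group. Also open, from the compounds shown here alone, is whether a bromine or fluorine in place of the chlorine would give a large step or a small one.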